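The source may report more compounds than this note shows. Statements on the series, on what has been measured and on what is new or still open speak of the compounds shown alone.

Three compounds with a shared sulfonamide-linked core open the account. Compound 1 `Cc1ccc(NS(=O)(=O)c2ccc3ccccc3c2)cc1Nc1nccc(-c2cccnc2)n1` gives 8310 nM in a functional assay on MDA-MB-231 cells (Homo sapiens) for cytotoxicity, read by MTT assay, with a stated time of 24 h; a lower number here means a stronger inhibitor, a higher number a weaker inhibitor. Compound 2 `COc1ccc(S(=O)(=O)Nc2ccc(C)c(Nc3nccc(-c4cc(OC)c(OC)c(OC)c4)n3)c2)cc1` gives 6860 nM in this assay, and compound 3 `COc1ccc(S(=O)(=O)Nc2ccc(C)c(Nc3nccc(-c4cc(OC)c(OC)c(OC)c4)n3)c2)cc1OC` gives 7480 nM in this assay. Among the compounds with values here, the only measured step among them, a 1.1-fold higher number from compound 2 to compound 3 (0.04 log units; within the scatter), is within the scatter. On the numbers shown, compound 3 holds nominally the second highest value of three, but its nearest neighbour is compound 2 and its furthest is compound 1, and both lie within the scatter of it, so no order can be drawn among the three.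

Compound 4 `COc1cc(-c2ccnc(Nc3cc(NS(=O)(=O)c4ccc5ccccc5c4)ccc3C)n2)cc(OC)c1OC` is not yet measured. It differs from compound 3 by naphthalen-2-yl in place of 3,4-dimethoxyphenyl on a sulfonyl sulfur. Within the data shown here, no measured step covers this change. Two pieces of evidence bear on it: compound 1 carries the same naphthalen-2-yl on the sulfonyl sulfur and its value sits within the scatter of compound 3, and the step of a 1.1-fold higher number from compound 2 to compound 3 (0.04 log units; within the scatter) shows that altering the sulfonyl-bound ring left the number within the scatter. Compound 4 is therefore expected to show a 1.0-fold higher number from compound 3 to compound 4 (0.00 log units; within the scatter), no step beyond the scatter. Compound 4 is estimated at 7500 nM, with a range from 4000 nM to 14000 nM.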

Compound 4, half-maximal inhibitory concentration: 7550 nM
For compound 4 the middle estimate is 1.0-fold (0.00 log units) below the measured one; measured number inside the range.
By their numbers in this assay, from the lowest: compounds 2, 3, 4 and 1 (each within the scatter of the next).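

With 3,4,5-trimethoxyphenyl held on the aromatic carbon, this assay now compares the groups on the sulfonyl sulfur directly: a 1.0-fold higher number from compound 3 to compound 4 (0.00 log units; within the scatter) comes from naphthalen-2-yl in place of 3,4-dimethoxyphenyl, and a 1.1-fold higher number from compound 2 to compound 4 (0.04 log units; within the scatter) comes from naphthalen-2-yl in place of 4-methoxyphenyl, so at this place a ring system of carbon only with no hydrogen-bond acceptors reads the same as either methoxy-bearing ring. Compound 4 also supplies the first single-place comparison with compound 1, since a 1.1-fold lower number from compound 1 to compound 4 (0.04 log units; within the scatter) arises from 3,4,5-trimethoxyphenyl in place of pyridin-3-yl on an aromatic carbon, and so neither place has yet shifted the number beyond the scatter in the four compounds shown. Nothing in the material offers an account of why these values stay together.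

On these data alone, whether any group on the sulfonyl sulfur can separate from the rest stays open, for instance a ring carrying an amine or a carboxylic acid, or a longer alkyl chain in place of a ring. As far as these compounds go, the aromatic carbon is equally open, as only pyridin-3-yl and 3,4,5-trimethoxyphenyl appear there, with nothing yet known for a morpholine ring at that place.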